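Pyridin-4-yl for thiophen-3-yl on the carbonyl of compound 2

The source may report more compounds than this note shows. Statements on the series, on what has been measured and on what is new or still open speak of the compounds shown alone.

In a functional assay on A2780 cells (Homo sapiens) for antiproliferative activity, read by fluorescence, with a stated time of 72 h (on this read-out lower numbers stand for stronger inhibition and higher numbers for weaker inhibition), compound 2 `CN1CCC(C(=O)N2Cc3c(NC(=O)c4ccsc4)n[nH]c3C2(C)C)CC1` gives 140 nM. Compound 1 `CC(C)(C)C(=O)N1Cc2c(NC(=O)c3ccc(F)cc3)n[nH]c2C1(C)C` gives 270 nM, which lies within the scatter of compound 2, so these two are not ranked. Compound 3 `CN(C)CC(=O)Nc1n[nH]c2c1CN(C(=O)C(C)(C)C)C2(C)C` gives 580 nM, a higher number than that of compound 2 and beyond the scatter.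

Compound 4 `CN1CCC(C(=O)N2Cc3c(NC(=O)c4ccncc4)n[nH]c3C2(C)C)CC1` carries pyridin-4-yl in place of thiophen-3-yl on a carbonyl carbon whose other neighbour is an amide-type nitrogen: pyridin-4-yl in place of thiophen-3-yl on a carbonyl carbon. A five-membered aromatic ring thus gives way to a six-membered one, each with one hetero atom.

Within the data shown here, the only measured step at a carbonyl of this type is a 2.1-fold higher number from compound 1 to compound 3 (0.33 log units; beyond the scatter), a modest change with (dimethylamino)methyl in place of 4-fluorophenyl. That step replaces an aromatic ring with a group that has none, whereas the change here keeps an aromatic ring. Among the measured compounds shown here, no measured step exchanges one aromatic ring for another directly, so the evidence is indirect. On the modest size of that step, a shift beyond the scatter is not expected in this assay, and any drift is expected to be slightly upward. The expected change is a 1.4-fold higher number from compound 2 to compound 4 (0.15 log units; within the scatter). In this assay the estimate for compound 4 is 200 nM, with an expected range of 80 nM to 500 nM.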

Compound 4, half-maximal inhibitory concentration: 500 nM
For compound 4 the middle estimate is 2.5-fold (0.40 log units) below the measured one; the measured number falls inside the stated range.
By their numbers in this assay, from the lowest: compounds 2, 1, 4 and 3 (each within the scatter of the next, the first and the last beyond it).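

In this assay, the exchange of one aromatic ring for another on this carbonyl carbon does not leave the number in place: pyridin-4-yl for thiophen-3-yl gives a 3.6-fold higher number from compound 2 to compound 4 (0.55 log units; beyond the scatter). Among these compounds, the only earlier step at a carbonyl of this type, a 2.1-fold higher number from compound 1 to compound 3 (0.33 log units; beyond the scatter), removed the aromatic ring altogether, so it could not show whether a compound that keeps an aromatic ring here also keeps its number; the pair of compound 2 and compound 4 shows that, at least for these two rings, it does not, with the rest of the structure unchanged and both groups counted with the same hydrogen-bond donors and acceptors. Nothing measured here accounts for the size of this step, which so far rests on a single pair.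

Still open, going by these compounds, is whether the step follows the change from a five-membered to a six-membered ring or the change of hetero atom, which a plain phenyl, a pyridin-3-yl or a furan-3-yl on this carbonyl, with the rest of compound 2 kept, could help to separate. Also open, on these data alone, is whether the same exchange gives a similar step when the pivaloyl-bearing core of compound 1 replaces that of compound 2.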